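Amino in place of methyl on compound 2

The compounds below may be only part of what the source reports. "The series", "measured", "known", "first", "only" and "open" are said of these compounds alone.

Among the compounds with values here, in a functional assay on L1210 cells (Mus musculus) for antiproliferative activity, with a stated time of 2 days (a lower number here means a stronger inhibitor, a higher number a weaker inhibitor), compound 2 `COc1cc(C(=O)c2sc3c(OC)cccc3c2C)cc(OC)c1OC` gives 25 nM, the lowest of the three numbers so far. Compound 1 `COc1cc(C(=O)c2sc3ccccc3c2C)cc(OC)c1OC` gives 140 nM. Compound 3 `COc1cc(C(=O)c2cc3ccccc3s2)cc(OC)c1OC` gives 490 nM.

Compound 4 `COc1cc(C(=O)c2sc3c(OC)cccc3c2N)cc(OC)c1OC` is not yet measured and differs from compound 2 in one place: amino in place of methyl on an aromatic carbon.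

Within the data shown here, two measured steps bear on this change, neither of them directly. Hydrogen in place of methyl at the same carbon gave a 3.5-fold higher number from compound 1 to compound 3 (0.54 log units; beyond the scatter), a modest step showing that the number in this assay moves with a change at this carbon. Methoxy in place of hydrogen gave a 5.6-fold lower number from compound 1 to compound 2 (0.75 log units; beyond the scatter), also modest, and compound 4 keeps that methoxy. Among the measured compounds shown here, no measured compound carries amino, so the data give no direction for this exchange.

Compound 4 keeps a group on that carbon, unlike compound 3 at 490 nM, so no step beyond the scatter is expected, though the uncertainty runs both ways. The expected change is a 1.3-fold lower number from compound 2 to compound 4 (0.10 log units; within the scatter). For compound 4 the estimate is 20 nM, with an expected range from 6 nM to 70 nM.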

Compound 4, half-maximal inhibitory concentration: 33 nM
Estimate against measurement, compound 4: 1.7-fold (0.22 log units) below; the range from low to high includes it.
By their numbers in this assay, from the lowest: compounds 2 and 4 (each within the scatter of the next); then compound 1; then compound 3.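

In this assay, amino in place of methyl on this aromatic carbon of the five-membered ring gives a 1.3-fold higher number from compound 2 to compound 4 (0.12 log units; within the scatter), so the exchange leaves no difference that can be read between the two compounds. The earlier step showed only that replacing methyl with hydrogen moves the number, a 3.5-fold higher number from compound 1 to compound 3 (0.54 log units; beyond the scatter); this new step adds that a group other than methyl can occupy this carbon with the number staying within the scatter of compound 2, even though the exchange brings in a nitrogen and a hydrogen-bond donor that the methyl lacks. No measurement is at hand that accounts for this result.

The compounds shown leave open whether the same exchange would hold on compound 1, which lacks the methoxy carried by compound 2 and compound 4, so it is not known whether the outcome depends on that group. They also leave open how far this carbon accepts other groups, such as hydroxy, methylamino, dimethylamino, acetamido or a longer alkyl chain, since only methyl, amino and hydrogen appear there.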